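Swapping the aryl amine on a urea-bearing core

The source may hold more compounds than are shown below. What is called first, only, known or untested is meant among the compounds shown, and "the series" means these compounds.

Compound 3 `Cc1cc(F)cc(Nc2cc(NC(=O)Nc3c(Cl)cccc3Cl)ncn2)c1` gives the largest number of the three measured compounds in a functional assay on NCI-H226 cells (Homo sapiens) for inhibition, read by MTT assay, with a stated time of 48 h, tested at 10 uM (a lower number here means less inhibition, a higher number more inhibition at the concentration tested (going by the name of the read-out)), with 78.1%. Compound 1 `CCc1ccc(Nc2cc(NC(=O)Nc3cc(OC)cc(OC)c3)ncn2)cc1` gives 50.1% in this assay, and compound 2 `COc1cc(NC(=O)Nc2cc(Nc3ccc(C)c(C)c3)ncn2)cc(OC)c1` gives 45.3%; the gap from each of these to compound 3 is larger than the usual scatter.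

Compound 4 `CCc1ccc(Nc2cc(NC(=O)Nc3c(Cl)cccc3Cl)ncn2)cc1` has not yet been measured. It keeps the dichlorophenyl urea of compound 3 and changes only the group on the nitrogen: 4-ethylphenyl in place of 3-fluoro-5-methylphenyl on a nitrogen on an aromatic ring.

One measured step speaks to this kind of exchange. The step of a number 4.8 percentage points lower from compound 1 to compound 2 (within the scatter) changed the same aryl group on the same nitrogen, though on compounds carrying the dimethoxyphenyl urea, and it stayed within the scatter. That suggests the aryl group on this nitrogen shifts the read-out only modestly, while the urea partner, which compound 3 and compound 4 share, appears to matter more. The expected step is therefore small and in either direction, most likely a slight drop, so compound 4 is expected to show a number 8.1 percentage points lower from compound 3 to compound 4 (within the scatter).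

In this assay compound 4 is estimated at 70%, with a range from 50% to 85%.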

Compound 4, a percentage reported as inhibition, at one concentration (the size of the read-out at that concentration, not a potency): 39.5%
Estimate against measurement, compound 4: 30.5 percentage points above; measured number outside the range, below it.
By their numbers in this assay, from the lowest: compounds 4, 2 and 1 (each within the scatter of the next, the first and the last beyond it); then compound 3.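

In this assay, putting 4-ethylphenyl in place of 3-fluoro-5-methylphenyl on a nitrogen on an aromatic ring gives a number 38.6 percentage points lower from compound 3 to compound 4 (beyond the scatter), so with the dichlorophenyl urea in place, this position can move the read-out strongly. The earlier exchange at this position, on the dimethoxyphenyl urea, gave a number 4.8 percentage points lower from compound 1 to compound 2 (within the scatter), so a small step with one pair of aryl groups on one urea does not predict the step with another pair on another urea, and the dichlorophenyl urea alone does not secure a high number. No measurement here explains the drop.

The exchange alters more than one feature at once: the fluorine and the methyl both leave and an ethyl enters, so these compounds cannot show which of those changes accounts for the step. As far as these compounds go, it also remains open how this aryl group would behave if it carried an amine, a carboxylic acid or a chain longer than ethyl, and whether any such group would hold the number seen with the 3-fluoro-5-methylphenyl group.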